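This account rests on a few compounds, and the source may have more. Where it says the series, first, only, none or still open, it means among the compounds named here.

Compound 1, `CCOc1ccc(C2C(C3CC3)C(=O)N2c2cc(OC)c(OC)c(OC)c2)cc1`, was tested in a functional assay on HT-29 cells (Homo sapiens) for inhibition, read by sulforhodamine B assay, with a stated time of 72 h (on this read-out higher numbers stand for weaker inhibition and lower numbers for stronger inhibition), where compound 1 gives 63 nM. Compound 2, `COc1cc(N2C(=O)C(C3CC3)C2c2ccc(SC)cc2)cc(OC)c1OC`, differs from compound 1 in one place: methylsulfanyl in place of ethoxy on an aromatic carbon. In this assay compound 2 gives 204 nM, so that a 3.2-fold higher number from compound 1 to compound 2 (0.51 log units; beyond the scatter).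

Compound 3, `CCOc1ccc(C2C(O)C(=O)N2c2cc(OC)c(OC)c(OC)c2)cc1`, keeps the 4-ethoxyphenyl group of compound 1 but differs from it on the four-membered ring: hydroxy in place of cyclopropyl on a saturated ring carbon. In this assay compound 3 gives 15 nM, and a 4.2-fold lower number from compound 1 to compound 3 (0.62 log units; beyond the scatter). Among the three measured compounds, compound 3 carries the lowest number, with compound 1 nearest and compound 2 furthest.

Compound 4, `COc1cc(N2C(=O)C(O)C2c2ccc(SC)cc2)cc(OC)c1OC`, has not yet been measured in this assay. It stands to compound 3 as compound 2 stands to compound 1: methylsulfanyl in place of ethoxy on an aromatic carbon. The surroundings of the exchanged group are described in the same words for both pairs, so it is the same change, made on two cores whose difference is given by hydroxy in place of cyclopropyl on a saturated ring carbon. The change has been measured once, from compound 1 to compound 2, where it gave a modest rise in the number.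

Resting on that single measured step, a 3.2-fold higher number from compound 1 to compound 2 (0.51 log units; beyond the scatter), the step from compound 3 to compound 4 is expected to be of similar size, a 3.2-fold higher number from compound 3 to compound 4 (0.51 log units; beyond the scatter). Compound 4 is therefore estimated at 48 nM in this assay, with a likely range from 20 nM to 120 nM.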

Compound 4, half-maximal inhibitory concentration: 15 nM
For compound 4 the middle estimate is 3.2-fold (0.51 log units) above the measured one; measured number outside the range, below it.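

On the core of compound 3, putting 4-(methylsulfanyl)phenyl in place of 4-ethoxyphenyl gave no change at the digits printed from compound 3 to compound 4 (within the scatter), so in this assay the rise seen on the core of compound 1 did not carry over to this second core: the same change on two cores in this assay, a 3.2-fold higher number (0.51 log units; beyond the scatter) from compound 1 to compound 2 and no change at the digits printed (within the scatter) from compound 3 to compound 4, 3.2-fold (0.51 log units) apart, beyond the scatter of two such steps. The same four compounds, read along the other edge, show that hydroxy in place of cyclopropyl gave a 14-fold lower number from compound 2 to compound 4 (1.13 log units; beyond the scatter), a larger step than on the ethoxy-bearing core: the same change on two cores in this assay, a 4.2-fold lower number (0.62 log units; beyond the scatter) from compound 1 to compound 3 and a 14-fold lower number (1.13 log units; beyond the scatter) from compound 2 to compound 4, 3.2-fold (0.51 log units) apart, beyond the scatter of two such steps. Within these four compounds, then, the effect of each change depends on the core that carries it, so a step measured on one core was not a safe guide to the other; the result rests on a single set of four compounds, however, and does not show why the steps differ or whether the same would hold for other groups or other cores in the series.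

The compounds shown leave open how other groups on the same aromatic carbon, such as an amine, a chlorine atom or a longer alkoxy chain, would behave on each of the two cores. They also leave open whether a methoxy group or an amine in place of the hydroxy on the saturated ring carbon would keep the low numbers of compound 3 and compound 4.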